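Replacing Iodo with Nitro: An Expected Step

This account rests on a few compounds, and the source may have more. Where it says the series, first, only, none or still open, it means among the compounds named here.

- Compound 1 `O=C(CCCCCCC(=O)Nc1ccc(C(F)(F)F)cc1)NO`: 450 nM
- Compound 2 `O=C(CCCCCCC(=O)Nc1ccc(Cl)cc1)NO`: 550 nM
- Compound 3 `O=C(CCCCCCC(=O)Nc1ccc(I)cc1)NO`: 120 nM

In a functional assay on U-937 cells (Homo sapiens) for antiproliferative activity, with a stated time of 48 h (a lower number here means that less compound is needed, a higher number that more compound is needed for the effect), compound 3 gives 120 nM, the lowest number of the three measured compounds. Compound 4 `O=C(CCCCCCC(=O)Nc1ccc([N+](=O)[O-])cc1)NO` has nitro in place of iodo on an aromatic carbon, para to a large group (nitro in place of iodo on an aromatic carbon). Going by the values given here, no measured step involves nitro, so the evidence is indirect. Among the compounds with values here, two steps bear on the change, and both end at the iodo compound: a 3.8-fold lower number from compound 1 to compound 3 (0.57 log units; beyond the scatter), and a 4.6-fold lower number from compound 2 to compound 3 (0.66 log units; beyond the scatter). Both are modest. The remaining step, between the two compounds without iodo, stays within the scatter: a 1.2-fold higher number from compound 1 to compound 2 (0.09 log units; within the scatter). Losing iodo is therefore expected to reverse a step of about that modest size, though nitro may not behave like trifluoromethyl or chloro. The expected change in this assay is a 3.3-fold higher number from compound 3 to compound 4 (0.52 log units; beyond the scatter). For compound 4 the estimated value is 400 nM, with an expected range from 150 nM to 1000 nM.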

Compound 4, half-maximal effective concentration: 22000 nM
Compound 4: the middle estimate sits 55-fold (1.74 log units) below what was measured; measured number outside the range, above it.
By their numbers in this assay, from the lowest: compound 3; then compounds 1 and 2 (each within the scatter of the next); then compound 4.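

In this assay nitro in place of iodo gives a 180-fold higher number from compound 3 to compound 4 (2.26 log units; beyond the scatter) and fares no better against the other two groups, with a 40-fold higher number from compound 2 to compound 4 (1.60 log units; beyond the scatter) and with a 49-fold higher number from compound 1 to compound 4 (1.69 log units; beyond the scatter) on the same aromatic carbon. The earlier exchanges among trifluoromethyl, chloro and iodo at this place had moved the number only modestly, whereas this change shows that the same place can carry a far larger loss. Compound 4 therefore stands apart from all three other compounds, and the choice of group at this place can decide much of the result in this assay for this chain and core.

From the compounds shown here alone, with a single nitro compound, it stays open whether this loss belongs to nitro alone or would also appear with a nitrile or an amine at this place. No measurement given here explains the large step.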